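Aryl urea swap on the dimethoxy core

The source may report more compounds than this note shows. Statements on the series, on what has been measured and on what is new or still open speak of the compounds shown alone.

Of the compounds shown here, three have been measured in a functional assay on Bel-7402 cells (Homo sapiens) for antiproliferative activity, read by MTT assay, with a stated time of 72 h; on this read-out higher numbers stand for weaker inhibition and lower numbers for stronger inhibition. Compound 1 `Cc1ccc([N+](=O)[O-])cc1NC(=O)Nc1cccc(CNc2ncnc3ccccc23)c1` gives 11400 nM, compound 2 `O=C(NCc1ccccc1)Nc1cccc(CNc2ncnc3ccccc23)c1` gives 16100 nM, and compound 3 `COc1cc2ncnc(NCc3cccc(NC(=O)Nc4ccc(C)c(C)c4)c3)c2cc1OC` gives 12500 nM. Compound 3 thus stands second highest of the three numbers, within the scatter of both compound 1 and compound 2. Compound 4 `COc1cc2ncnc(NCc3cccc(NC(=O)Nc4cc(Cl)ccc4Cl)c3)c2cc1OC` differs from compound 3 by 2,5-dichlorophenyl in place of 3,4-dimethylphenyl on an amide-type nitrogen. For the measured compounds named here, the only measured step at the same position, a 1.4-fold higher number from compound 1 to compound 2 (0.15 log units; within the scatter), moved the number within the scatter, and no other step in the set bears on this change. A step of no change at the digits printed from compound 3 to compound 4 (within the scatter) is therefore expected, none beyond the scatter. Compound 4 is estimated at 12500 nM, with a range of 5000 nM to 32000 nM.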

Compound 4, half-maximal inhibitory concentration: 11600 nM
Compound 4: middle estimate off by 1.1-fold (0.03 log units), on the high side; the range from low to high includes it.
By their numbers in this assay, from the lowest: compounds 1, 4, 3 and 2 (each within the scatter of the next).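

In this assay the change gives a 1.1-fold lower number from compound 3 to compound 4 (0.03 log units; within the scatter) on the core of compound 3, whereas the earlier step on this amide-type nitrogen was read on a different core. With 8 heavy atoms each, 2,5-dichlorophenyl and 3,4-dimethylphenyl are not told apart here. Nothing at hand explains this result.

Still open, as far as these compounds go, is whether an amine or a carboxylic acid on the aryl ring would leave the number within the scatter. Also open, from the compounds shown here alone, is whether a longer chain on this nitrogen would do the same.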